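A few compounds are considered here, and "the series" means these few. Any claim that something is new, unique, unknown or untested is made for them only; others in the source may bear on it.

Measured compounds in a functional assay on WiDr cells (Homo sapiens) for inhibition, read by sulforhodamine B assay, with a stated time of 48 h; a lower number here means a stronger inhibitor of growth, a higher number a weaker inhibitor of growth:

Compound 1 `O=C(/C(=C/c1ccccc1)CCl)c1ccccc1` gives 18000 nM.
Compound 2 `O=C(/C(=C/c1ccc(Cl)cc1)CCl)c1ccccc1` gives 19000 nM.
Compound 3 `CC(=O)OC/C(=C/c1ccc(Cl)cc1)C(=O)c1ccc(Cl)cc1` gives 17000 nM.

Compound 2 differs from compound 1 by chloro in place of hydrogen on an aromatic carbon, and the step of a 1.1-fold higher number from compound 1 to compound 2 (0.02 log units; within the scatter). Compound 3 has a different core from compound 1; the difference between the two cores is not broken down here. Its value in this assay lies within the usual scatter of the values of compound 1 and compound 2, so the three measured compounds cannot be told apart.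

Compound 4 `CC(=O)OC/C(=C/c1ccc(Cl)cc1Cl)C(=O)c1ccc(Cl)cc1` has not yet been measured. It differs from compound 3 by chloro in place of hydrogen on an aromatic carbon. For the measured compounds named here, this is the same kind of change as the one from compound 1 to compound 2, but not the same: in compound 2 the entering chloro sits para to a large group, whereas in compound 4 it sits ortho to a large group and meta to a chloro group.

Since the earlier step of a 1.1-fold higher number from compound 1 to compound 2 (0.02 log units; within the scatter) stayed within the scatter, and since compound 3 gives 17000 nM, compound 4 is expected to land close to its parent, with an estimated step of a 1.1-fold lower number from compound 3 to compound 4 (0.05 log units; within the scatter). Compound 4 is therefore estimated at 15000 nM, with an expected range from 6000 nM to 40000 nM.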

Compound 4, concentration for 50% growth inhibition: 20000 nM
Compound 4: middle estimate off by 1.3-fold (0.12 log units), on the low side; the measured number falls inside the stated range.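

In this assay, chloro in place of hydrogen on an aromatic carbon, the change that turns 4-chlorophenyl into 2,4-dichlorophenyl, gives a 1.2-fold higher number from compound 3 to compound 4 (0.07 log units; within the scatter). Set beside a 1.1-fold higher number from compound 1 to compound 2 (0.02 log units; within the scatter), the same kind of change reads alike on the two cores, and no difference between them can be resolved: the same change on two cores in this assay, a 1.1-fold higher number (0.02 log units; within the scatter) from compound 1 to compound 2 and a 1.2-fold higher number (0.07 log units; within the scatter) from compound 3 to compound 4, 1.1-fold (0.05 log units) apart, within the scatter of two such steps. For the compounds shown here, this shows only that the change left the growth-inhibition number unresolved from its parent on both cores; it does not show that chloro has a real effect of a fixed size that carries over, since neither step rises above the scatter, and two cores are a narrow basis for any rule that reaches further, particularly as the chloro in compound 4 sits ortho to a large group and meta to a chloro group, a different place from the one it takes in compound 2.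

Every step shown brings in chloro, so the compounds leave open whether a methoxy group, an amine or a carboxylic acid on the same aromatic ring would move the number in this assay beyond the scatter. They also leave open whether chloro at this place would read the same on the core of compound 1.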